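Swapping 2-acetoxybutyl for (oxolan-3-yl)carbonyl in compound 3

The source may report more compounds than this note shows. Statements on the series, on what has been measured and on what is new or still open speak of the compounds shown alone.

Measured in a functional assay on DU-145 cells (Homo sapiens) for cytotoxicity, read by MTT assay; a higher number here means a weaker inhibitor, a lower number a stronger inhibitor:
- compound 1 `CC(C)=CC[C@@H](OC[C@H](C)O)C1=CC(=O)c2c(O)ccc(O)c2C1=O`: 24500 nM
- compound 2 `CC(C)=CC[C@@H](OC(=O)c1ccco1)C1=CC(=O)c2c(O)ccc(O)c2C1=O`: > 100000 nM
- compound 3 `CCC(CO[C@H](CC=C(C)C)C1=CC(=O)c2c(O)ccc(O)c2C1=O)OC(C)=O`: 25400 nM

The value for compound 2 is a limit of the assay and not a number. For the measured compounds named here, compound 3 stands at 25400 nM, level with the only other true number, the measured step being a 1.0-fold higher number from compound 1 to compound 3 (0.02 log units; within the scatter).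

The next compound is compound 4 `CC(C)=CC[C@@H](OC(=O)C1CCOC1)C1=CC(=O)c2c(O)ccc(O)c2C1=O`, with (oxolan-3-yl)carbonyl in place of 2-acetoxybutyl on an oxygen on a saturated carbon.

Going by the values given here, compound 2 is the one measured compound that also carries a carbonyl-linked five-membered ring at this place, so two steps bear most directly: an at least 4.0-fold higher number from compound 1 to compound 2 (0.61 log units; beyond the scatter), and an at least 3.9-fold lower number from compound 2 to compound 3 (0.59 log units; beyond the scatter). Both are bounded by a limit, and compound 4 differs from compound 2 in having a non-aromatic ring, so the guide is loose. A modest move to a higher number in this assay is therefore expected. The expected step is a 2.2-fold higher number from compound 3 to compound 4 (0.34 log units; beyond the scatter). For compound 4 the estimated value is 55000 nM, with an expected range of 20000 nM to 130000 nM.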

Compound 4, half-maximal inhibitory concentration: 47500 nM
For compound 4 the middle estimate is 1.2-fold (0.06 log units) above the measured one; the measured number falls inside the stated range.
By their numbers in this assay, from the lowest: compounds 1, 3 and 4 (each within the scatter of the next). At a limit, above all of these: compound 2.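

In this assay, oxolan-3-yl in place of furan-2-yl on the carbonyl carbon gives an at least 2.1-fold lower number from compound 2 to compound 4 (0.32 log units; beyond the scatter), so a carbonyl-linked five-membered ring at this place does not by itself leave a compound at the limit. The value of compound 2 is a limit of the assay and the only one in this set: the limit of > 100000 nM in this assay, at which 1 of the 4 values shown sits.

Against the open chains 2-acetoxybutyl and 2-hydroxypropyl, the (oxolan-3-yl)carbonyl group brings no change beyond the scatter, with a 1.9-fold higher number from compound 3 to compound 4 (0.27 log units; within the scatter) and a 1.9-fold higher number from compound 1 to compound 4 (0.29 log units; within the scatter).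

The compounds shown leave open whether an amine on this ring, or a longer chain on the oxygen, would move the number beyond the scatter. They also leave open how large the gap between the two ring groups really is, since one side of it is only a limit.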